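Trimming a Benzyl Ether to a Bromopropyl Chain

A few compounds are considered here, and "the series" means these few. Any claim that something is new, unique, unknown or untested is made for them only; others in the source may bear on it.

Three brominated diaryl ethers have been tested in a functional assay on HL-60 cells (Homo sapiens) for cytotoxicity, read by MTT assay, with a stated time of 24 h; on this read-out lower numbers stand for stronger inhibition and higher numbers for weaker inhibition. Compound 1 `CC(C)(C)OC(=O)N1CCCN(CCCCCOc2c(Br)cc(Br)cc2Oc2ccc(Br)cc2Br)CC1` gives 44.8 ug/mL, and compound 2 `Brc1ccc(Oc2cc(Br)cc(Br)c2OCCCCCN2CCN(C/C=C/c3ccccc3)CC2)c(Br)c1` gives 47.2 ug/mL. Compound 3 `Brc1ccc(Oc2cc(Br)cc(Br)c2OCc2ccccc2)c(Br)c1` gives 27.9 ug/mL, the lowest of the three numbers, though its gaps to compound 1 and to compound 2 both lie within the scatter, so no order among them can be claimed. Compound 4 `BrCCCOc1c(Br)cc(Br)cc1Oc1ccc(Br)cc1Br` has not yet been measured in this assay. It differs from compound 3 in one place: 2-bromoethyl in place of phenyl on a saturated chain carbon bound to an oxygen on an aromatic ring. Within the data shown here, no step between measured compounds shows what such a change does; with the three known values all within scatter of one another, the change is expected to bring no step beyond the scatter, a 1.1-fold higher number from compound 3 to compound 4 (0.03 log units; within the scatter). Compound 4 is therefore estimated at 30 ug/mL, with a range from 15 ug/mL to 60 ug/mL.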

Compound 4, half-maximal inhibitory concentration: 29.9 ug/mL
Compound 4: the middle estimate sits 1.0-fold (0.00 log units) above what was measured; the measured number falls inside the stated range.
By their numbers in this assay, from the lowest: compounds 3, 4, 1 and 2 (each within the scatter of the next).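

In this assay, going from benzyl to 3-bromopropyl on the ether oxygen brings a 1.1-fold higher number from compound 3 to compound 4 (0.03 log units; within the scatter). At this position, then, the phenyl ring can give way to a ring-free 2-bromoethyl group, with three heavy atoms in place of six, without a change that can be told from the scatter. No measurement at hand accounts for this result. The compounds shown leave open whether a 3-hydroxypropyl group or a chain ending in a carboxylic acid, in place of 3-bromopropyl, would bring a step beyond the scatter.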